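The source may report more compounds than this note shows. Statements on the series, on what has been measured and on what is new or still open speak of the compounds shown alone.

Compound 1 `CC(C)=CCC1Cc2c(OC(=O)Nc3ccc(Cl)cc3)cc(=O)n(CCCO)c2CC1(C)C` and compound 2 `COc1ccccc1NC(=O)Oc1cc(=O)n(CCCO)c2c1CC(C/C=C(\C)CCC=C(C)C)C(C)(C)C2` differ only in the aryl group on the carbamate nitrogen. In a functional assay on PANC-1 cells (Homo sapiens) for inhibition, read by MTT assay, with a stated time of 24 h, tested at 10 uM (on this read-out higher numbers stand for more inhibition at the one concentration tested (going by the name of the read-out) and lower numbers for less inhibition), compound 1 gives 0%, and in this assay compound 2 gives 0%, level with compound 1 within the scatter. Compound 3 `CC(C)=CCC/C(C)=C/CC1Cc2c(OC(=O)Nc3ccc(Cl)cc3)cc(=O)n(CCCO)c2CC1(C)C` arises from compound 2 by a single change: 4-chlorophenyl in place of 2-methoxyphenyl on an amide-type nitrogen. Among the measured compounds shown here, no step between measured compounds is given. Compound 1 already carries the 4-chlorophenyl group and gives 0%. The step is therefore expected to stay within the scatter, no change at the digits printed from compound 2 to compound 3 (within the scatter). Compound 3 is expected to give 0%, between -8% and 10%.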

Compound 3, a percentage reported as inhibition, at one concentration (the size of the read-out at that concentration, not a potency): 4.3%
Compound 3: the middle estimate sits 4.3 percentage points below what was measured; low and high end bracket the measured number.
By their numbers in this assay, from the lowest: compounds 1, 2 and 3 (each within the scatter of the next).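

In this assay the step of 4-chlorophenyl in place of 2-methoxyphenyl on the amide-type nitrogen reads a number 4.3 percentage points higher from compound 2 to compound 3 (within the scatter) and stays within the scatter, so this aryl exchange leaves the read-out unmoved. The step of 3-methylbut-2-en-1-yl in place of hydrogen on the chain reads a number 4.3 percentage points higher from compound 1 to compound 3 (within the scatter) and likewise stays within the scatter. No supporting measurement bears on these results.

All three compounds lie within the scatter of one another, so neither position is shown to affect the read-out. On these data alone, whether an amine or a carboxylic acid on the aryl ring would change the number stays open.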